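A few compounds are considered here, and "the series" means these few. Any claim that something is new, unique, unknown or untested is made for them only; others in the source may bear on it.

Measured so far:
Compound 1, `CCOC(=O)CCCCCOc1ccc2c(=O)c(-c3ccc(O)cc3)coc2c1` — 5300 nM
Compound 2, `O=c1c(-c2ccc(O)cc2)coc2cc(OCCCCCCCCCO)ccc12` — > 9000 nM

In an assay (Cricetulus griseus) for inhibition of Monoamine oxidase (Homo sapiens) (a lower number here means a stronger inhibitor, a higher number a weaker inhibitor), compound 1 gives 5300 nM. For compound 2 this assay reports only a limit, > 9000 nM. Among the measured compounds shown here, the single measured step, an at least 1.6-fold higher number from compound 1 to compound 2 (0.22 log units; that floor lies within the scatter), therefore rests on the limit of > 9000 nM in this assay, at which 1 of the 2 values shown sits, and carries no exact size. Compound 3, `O=c1c(-c2ccc(O)cc2)coc2cc(OCCCCCCO)ccc12`, differs from compound 2 by hydroxy in place of 3-hydroxypropyl on a saturated chain carbon, six bonds along the chain from an oxygen on an aromatic ring; it shortens the hydroxyalkyl chain while keeping the hydroxy end. For the measured compounds named here, no measured step touches a change of this kind, and the one step known, an at least 1.6-fold higher number from compound 1 to compound 2 (0.22 log units; that floor lies within the scatter), runs from an ester end to a hydroxy end rather than along chain length. Compound 3 is thus expected to stay near compound 2, with a sizeable chance that this assay again reports only a limit; the estimated step of a number no higher from compound 2 to compound 3 (the limit leaves the size open) is within the scatter. Compound 3 is estimated at 9000 nM, between 3000 nM and 30000 nM.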

Compound 3, half-maximal inhibitory concentration: > 9000 nM
Compound 3: only a limit was reported; the forecaster's own chance of this, stated with the estimate: 55%; the middle value lies on the limit itself.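

In this assay compound 3 gives only a limit, > 9000 nM, so shortening the hydroxyalkyl chain of compound 2 yields no exact value, and the step between these two cannot be read. Set against the ester end, the hydroxy-ended chain of compound 3 gives an at least 1.6-fold higher number from compound 1 to compound 3 (0.22 log units; that floor lies within the scatter), the same floor as the longer chain gave, so neither chain length is shown to differ from the ester. Chain length cannot be ranked among the hydroxy-ended compounds, because both sit at the same limit: the limit of > 9000 nM in this assay, at which 2 of the 3 values shown sit.

As far as these compounds go, it remains open whether a hydroxy-ended chain of any length gives a readable number in this assay. Among the compounds shown here, also open is how an amine or a carboxylic acid at the chain end would compare with the ester end of compound 1, whose 5300 nM is the only exact value here.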